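The source may hold more compounds than are shown below. What is called first, only, known or untested is meant among the compounds shown, and "the series" means these compounds.

Working notes on the series. In a functional assay on CHO cells (Homo sapiens) for antiproliferative activity against CHO (Cricetulus griseus), read by sulforhodamine B assay, with a stated time of 48 h (on this read-out lower numbers stand for stronger inhibition and higher numbers for weaker inhibition), compound 1 (`CCc1cccc(NS(=O)(=O)c2ccc(N3CCNC3=O)cc2)c1`) gives 230 nM, compound 2 (`O=C1NCCN1c1ccc(S(=O)(=O)Nc2cccc(Br)c2)cc1`) gives 250 nM, and compound 3 (`Cc1cc(C)cc(NS(=O)(=O)c2ccc(N3CCNC3=O)cc2)c1`) gives 210 nM. Compound 3 cannot be separated from the other two on these numbers: the steps are a 1.1-fold lower number from compound 1 to compound 3 (0.04 log units; within the scatter) and a 1.2-fold lower number from compound 2 to compound 3 (0.08 log units; within the scatter).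

Compound 4 (`O=C1NCCN1c1ccc(S(=O)(=O)Nc2cccc(Cl)c2)cc1`) has 3-chlorophenyl in place of 3,5-dimethylphenyl on a sulfonamide nitrogen.

The nearest evidence is the exchange of 3-bromophenyl for 3,5-dimethylphenyl at that nitrogen, seen in a 1.2-fold lower number from compound 2 to compound 3 (0.08 log units; within the scatter). Also relevant is bromo in place of ethyl, seen in a 1.1-fold higher number from compound 1 to compound 2 (0.04 log units; within the scatter). Within the data shown here, no chloro compound has been measured yet, so the halogen comparison rests on compound 2 alone. With every measured step this small, no step beyond the scatter is expected in this assay, and no direction can be favoured. The estimated step is a 1.1-fold higher number from compound 3 to compound 4 (0.06 log units; within the scatter). Compound 4 is estimated at 240 nM, with an expected range of 130 nM to 430 nM.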

Compound 4, half-maximal inhibitory concentration: 96 nM
For compound 4 the middle estimate is 2.5-fold (0.40 log units) above the measured one; measured number below the stated range.
By their numbers in this assay, from the lowest: compound 4; then compounds 3, 1 and 2 (each within the scatter of the next).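

In this assay the aryl group on a sulfonamide nitrogen no longer looks flat: the 3-chlorophenyl compound stands apart from all three earlier compounds, with a 2.2-fold lower number from compound 3 to compound 4 (0.34 log units; beyond the scatter) and a 2.6-fold lower number from compound 2 to compound 4 (0.42 log units; beyond the scatter) and also a 2.4-fold lower number from compound 1 to compound 4 (0.38 log units; beyond the scatter). Chloro in place of bromo is enough on its own to give a modest step beyond the scatter, so the presence of a halogen on this aryl group does not by itself set the number, and compound 4 is the most potent of the four. Nothing measured here accounts for this result.

From the compounds shown here alone, whether the step is specific to chloro stays open, since the comparison holds no fluoro, iodo or trifluoromethyl group at this place. Going by these compounds, how a methoxy group, an amine or a carboxylic acid on this aryl group would read also remains unknown.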